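From compound 2 to compound 3: one halogen exchanged

This account rests on a few compounds, and the source may have more. Where it says the series, first, only, none or still open, it means among the compounds named here.

Measured so far in an ADME assay on HOS cells (Homo sapiens) for cytotoxicity; on this read-out lower numbers stand for stronger inhibition and higher numbers for weaker inhibition:
- compound 1 `O=C1c2ccc(O)c(O)c2C(=O)N1Cc1cccc(Cl)c1` gives 13300 nM
- compound 2 `O=C1c2ccc(O)c(O)c2C(=O)N1Cc1ccc(F)c(Cl)c1` gives 9540 nM

Going by the values given here, on these numbers compound 2, at 9540 nM, cannot be separated from the only other measured compound. Among the compounds with values here, the one measured step is a 1.4-fold lower number from compound 1 to compound 2 (0.14 log units; within the scatter) and it comes with fluoro in place of hydrogen on an aromatic carbon. The next structure is compound 3 `O=C1c2ccc(O)c(O)c2C(=O)N1Cc1ccc(Cl)c(Cl)c1` and it differs from compound 2 as follows: chloro in place of fluoro on an aromatic carbon, in words chloro in place of fluoro on an aromatic carbon. Within the data shown here, no measured pair exchanges fluoro for chloro, and the single step available stays within the scatter. In this assay no step beyond the scatter is therefore expected, and no direction can be favoured. The estimated step is a 1.2-fold lower number from compound 2 to compound 3 (0.08 log units; within the scatter) and it remains small. Compound 3 is expected at 8000 nM with an estimated range of 3500 nM to 18000 nM for this measurement.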

Compound 3, half-maximal inhibitory concentration: 4430 nM
Compound 3: middle estimate off by 1.8-fold (0.26 log units), on the high side, and the stated range covers the measured number.
By their numbers in this assay, from the lowest: compound 3; then compounds 2 and 1 (each within the scatter of the next).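

In this assay, the aromatic carbon ortho to a chloro group and para to a large group now gives a step beyond the scatter: exchanging fluoro for chloro there produces a 2.2-fold lower number from compound 2 to compound 3 (0.33 log units; beyond the scatter) (modest). Placing chloro instead of hydrogen on that carbon produces a 3.0-fold lower number from compound 1 to compound 3 (0.48 log units; beyond the scatter) (also modest), whereas fluoro in place of hydrogen gave only a 1.4-fold lower number from compound 1 to compound 2 (0.14 log units; within the scatter) and stayed within the scatter, so among these three compounds only chloro separates from hydrogen. Nothing available explains why chloro and fluoro differ at this carbon.

On these data alone, it remains open whether a larger halogen such as bromo would continue this direction, or whether a methyl or a methoxy group would have a similar effect. An amine or a carboxylic acid on the same carbon also remains untested by the compounds shown here.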